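Fimbrolide-type bromofuranones: acetate to free alcohol

The source may hold more compounds than are shown below. What is called first, only, known or untested is meant among the compounds shown, and "the series" means these compounds.

Measured compounds and their numbers in a functional assay on KB cells (Homo sapiens) for cytotoxicity; on this read-out lower numbers stand for an effect already at smaller amounts and higher numbers for an effect only at larger amounts of compound:
compound 1 `CCC[C@@H](OC(C)=O)C1=C(Br)C(=C(Br)Br)OC1=O` gives 3.5 ug/mL
compound 2 `CCC[C@@H](OC(C)=O)C1=C(Br)/C(=C/Br)OC1=O` gives 1 ug/mL
compound 3 `CCCCC1=C(Br)C(=C(Br)Br)OC1=O` is reported only as a limit, > 20 ug/mL

Compound 2 has the lowest of the two numbers shown; compound 1 sits at a higher number, the gap between the two being beyond the scatter. The value for compound 3 is a limit of the assay and not a number (the limit of > 20 ug/mL in this assay, at which 1 of the 3 values shown sits).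

The unmeasured compound 4 `CCC[C@@H](O)C1=C(Br)/C(=C/Br)OC1=O` differs from compound 2 by one change: hydrogen in place of acetyl on an oxygen on a saturated carbon. Cut one bond further out, this reads acetoxy to hydroxy, so the oxygen on the saturated chain carbon stays in place.

Among the compounds with values here, one measured step bears on this change, only partly. Going from compound 1 to compound 3, hydrogen took the place of the whole acetoxy group, and an at least 5.7-fold higher number from compound 1 to compound 3 (0.75 log units; beyond the scatter). That step removed the oxygen altogether; the present change keeps it and removes only the acetyl. The loss seen for compound 3 is therefore taken as an upper bound for what to expect here, and a smaller shift is anticipated in this assay, either none beyond the scatter or a modest move to higher numbers.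

For compound 4 the expected value is 2.5 ug/mL, with a range from 0.8 ug/mL to 8 ug/mL. This estimate corresponds to an expected step of a 2.5-fold higher number from compound 2 to compound 4 (0.40 log units; beyond the scatter).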

Compound 4, concentration for half-maximal effect: 0.1 ug/mL
Beside the measured number, compound 4's estimate is 25-fold (1.40 log units) above it; the whole stated range lies above it.
By their numbers in this assay, from the lowest: compound 4; then compound 2; then compound 1. At a limit, above all of these: compound 3.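

In this assay, removing only the acetyl gives a 10-fold lower number from compound 2 to compound 4 (1.00 log units; beyond the scatter), so on the core of compound 2 the acetyl is not needed for the effect at this chain carbon, and the free hydroxy carries the lowest number in the series. The earlier change at this carbon, hydrogen in place of acetoxy on the core of compound 1, gave an at least 5.7-fold higher number from compound 1 to compound 3 (0.75 log units; beyond the scatter) and ended at a limit of the assay for compound 3, so the two steps run in opposite directions and the earlier one cannot be read as a loss tied to the acetyl. Nothing shown here gives a reason for the size or direction of the new step.

Within the data shown here, whether hydroxy in place of acetoxy moves the number in the same way on the core of compound 1 stays open, and with only one step on each core the two directions cannot be separated from the difference between the cores. Also open, as far as these compounds go, is how this chain carbon responds to other groups in place of hydroxy, such as a methoxy, an amine or a longer ester like butyryloxy.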